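Swapping chloro for fluoro on the fused aromatic ring

A few compounds are considered here, and "the series" means these few. Any claim that something is new, unique, unknown or untested is made for them only; others in the source may bear on it.

Measured so far:
compound 1 `NC(=O)/C=C1\CCc2cc(Cl)ccc21` gives 0%
compound 2 `NC(=O)/C=C1\CCc2c(F)cc(F)cc21` gives 67%

Of the compounds shown here, two share the core of compound 1 and have been tested in a functional assay on the whole organism with Mus musculus as the target, at a dose of 100 mg/kg by the intraperitoneal route; on this read-out lower numbers stand for less inhibition and higher numbers for more inhibition at the one dose given (going by the name of the read-out). Compound 1 stands at the bottom of the two numbers; in this assay compound 1 gives 0%. Its nearest neighbour is compound 2, which in this assay gives 67%, a gap that lies beyond the scatter.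

Compound 3 `NC(=O)/C=C1\CCc2cc(F)ccc21` has not been measured. It differs from compound 1 in one place: fluoro in place of chloro on an aromatic carbon. Going by the values given here, no step between two measured compounds isolates this exact change, so the expectation rests on the two values shown. With compound 1 at the floor of the read-out, the expected step from compound 1 to compound 3 is upward but moderate, estimated as a number 30 percentage points higher from compound 1 to compound 3 (beyond the scatter). Compound 3 is therefore expected to give about 30% in this assay, within a wide band from 0% to 65%.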

Compound 3, a percentage reported as inhibition, in the whole organism at one dose (the size of the read-out at that dose, not a potency): 100%
For compound 3 the middle estimate is 70 percentage points below the measured one; the measured number lies above the stated range.
By their numbers in this assay, from the lowest: compound 1; then compound 2; then compound 3.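

In this assay the exchange of chloro for fluoro gives a number 100 percentage points higher from compound 1 to compound 3 (beyond the scatter) with nothing else in the structure altered. Going by these compounds alone, compound 1 and compound 2 differ in more than one place, so only this pair shows that the identity of the halogen alone, on this aromatic carbon, can decide the read-out at the one dose given. No measurement among the data explains why the exchange has so large an effect.

On these data alone, whether a bromo or a methoxy group on this same aromatic carbon would behave like chloro or like fluoro remains open, as does the result for a ring carrying no halogen at all. The amide is also the same throughout the compounds shown, so the effect of a carboxylic acid in its place cannot be judged.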